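Swapping 3-bromophenyl for 4-cyanophenyl on a shared core

The compounds below may be only part of what the source reports. "The series", "measured", "known", "first", "only" and "open" are said of these compounds alone.

Compound 1 `C#CCN(Cc1ccc2nc(C)nc(O)c2c1)c1cccc(CO)c1`: > 54000 nM (a limit)
Compound 2 `C#CCN(Cc1ccc2nc(C)nc(O)c2c1)c1cccc(Br)c1`: 5300 nM

Among the compounds with values here, in a functional assay on GC3/MTK- cells (Homo sapiens) for inhibition (a lower number here means a stronger inhibitor, a higher number a weaker inhibitor), compound 2 gives 5300 nM, the only actual number so far. Compound 1 reads > 54000 nM, and this is a limit of the assay, not a number.

Compound 3 `C#CCN(Cc1ccc2nc(C)nc(O)c2c1)c1ccc(C#N)cc1` has not yet been measured. It keeps the shared core of compound 2 but changes the group on the amine nitrogen: 4-cyanophenyl in place of 3-bromophenyl on an amine nitrogen.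

Within the data shown here, only one measured step bears on this change: an at least 10-fold lower number from compound 1 to compound 2 (1.00 log units; beyond the scatter), with bromo in place of hydroxymethyl on an aromatic carbon. It shows that swapping a group on this ring can move the result in this assay beyond the scatter. As far as these compounds go, that step starts from a limit, so its true size remains open. Among the measured compounds shown here, no measured compound carries a nitrile, and the step gives no direction for this new change.

A shift within the scatter is therefore the most reasonable expectation, though with wide uncertainty. The expected change is a 1.3-fold higher number from compound 2 to compound 3 (0.12 log units; within the scatter). For compound 3 the estimated value is 7000 nM, with an expected range of 1500 nM to 30000 nM.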

Compound 3, half-maximal inhibitory concentration: 5000 nM
Compound 3: the middle estimate sits 1.4-fold (0.15 log units) above what was measured; low and high end bracket the measured number.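

In this assay, a 1.1-fold lower number from compound 2 to compound 3 (0.03 log units; within the scatter), so 3-bromophenyl and 4-cyanophenyl on the amine nitrogen cannot be told apart, although this change alters both the group on the ring and its place there. From the other side, an at least 10-fold lower number from compound 1 to compound 3 (1.03 log units; beyond the scatter), which means that two quite different replacements for 3-(hydroxymethyl)phenyl, one carrying a bromo group and one a nitrile, both give a clearly lower number than compound 1 and land level with each other. The true size of this step stays open because compound 1 stands at a limit rather than at a number: the limit of > 54000 nM in this assay, at which 1 of the 3 values shown sits.

Since the kind of group and its place on the ring change together between compound 2 and compound 3, the compounds shown cannot say whether either matters alone, or whether the two effects happen to cancel out. As far as these compounds go, it also remains open how a ring with a carboxylic acid, an amine or a methoxy group would read here, and whether any group at this place can bring the number well below the level shared by compound 2 and compound 3.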